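This account rests on a few compounds, and the source may have more. Where it says the series, first, only, none or still open, it means among the compounds named here.

Measured so far in an assay on HEK293 cells for agonist activity at Toll-like receptor 8 (Homo sapiens), read by a luciferase reporter, with a stated time of 6 h; a lower number here means that less compound is needed, a higher number that more compound is needed for the effect:
- compound 1 `CCCCNc1nc(N)nc2c1CN(C)CC2`: 0.03 uM
- compound 2 `CCCCNc1nc(N)nc2c1CN(Cc1ccc(OC(F)(F)F)cc1)CC2`: 0.24 uM
- compound 3 `CCCCNc1nc(N)nc2c1CN(Cc1c[nH]c3ccccc13)CC2`: 0.22 uM

Compound 1 has the lowest number of the three; compound 3 and compound 2 both sit higher, and both gaps lie beyond the scatter. The two larger substituents on the ring amine thus both cost activity relative to the methyl.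

Compound 4 `CCCCNc1nc(N)nc2c1CN(C(=O)c1scnc1C)CC2` is not yet measured. It differs from compound 1 in one place: (4-methyl-1,3-thiazol-5-yl)carbonyl in place of methyl on an amine nitrogen in a ring. Going by the values given here, no measured pair covers this kind of change, so the expectation rests only on compounds 2 and 3, where enlarging the group on that nitrogen raised the number. An increase beyond the scatter is expected, likely larger than that seen for compound 2 or compound 3. The estimate for compound 4 is 1 uM (range 0.2 uM to 5 uM), a step of a 33-fold higher number from compound 1 to compound 4 (1.52 log units; beyond the scatter).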

Compound 4, minimum effective concentration: 5.6 uM
Estimate against measurement, compound 4: 5.6-fold (0.75 log units) below, and the stated range ends below it.
By their numbers in this assay, from the lowest: compound 1; then compounds 3 and 2 (each within the scatter of the next); then compound 4.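

In this assay, going by these compounds alone, the ring amine nitrogen proves far more sensitive to substitution than the earlier compounds indicated, with a step of a 190-fold higher number from compound 1 to compound 4 (2.27 log units; beyond the scatter). By the printed values, compound 4 also stands above compounds 2 and 3, so a group here can cost more than those two showed. No evidence bearing on this result is available.

As far as these compounds go, compound 4 carries the carbonyl and the thiazole ring together, so the source of the loss stays open. An acetyl group and a (4-methyl-1,3-thiazol-5-yl)methyl group on this nitrogen would separate the two.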